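From Methoxyphenyl to Methylphenyl on the Amide Nitrogen

This account rests on a few compounds, and the source may have more. Where it says the series, first, only, none or still open, it means among the compounds named here.

Measured so far:
compound 1 `CC(C)[C@@H]1CC[C@@H](C)C[C@@]12N(C)C(=O)[C@@H]1[C@H]3C(=O)N(C)C(=O)[C@H]3ON12`, in a functional assay, read by spectrophotometry, with a stated time of 2 h, tested at 0.5 mg/mL; on this read-out higher numbers stand for a stronger effect at the one concentration tested and lower numbers for a weaker effect: 36.5%
compound 2 `COc1ccc(N2C(=O)[C@H]3[C@H](ON4[C@@H]3C(=O)N(C)[C@@]43C[C@H](C)CC[C@H]3C(C)C)C2=O)cc1`, in this assay: 44.5%

Compound 2 holds the higher of the two numbers shown in this assay, but its only neighbour is compound 1, and the step of a number 8 percentage points higher from compound 1 to compound 2 (within the scatter) lies within the scatter, so the two compounds cannot be told apart on this read-out. Going by the values given here, that single step, 4-methoxyphenyl in place of methyl on an amide-type nitrogen in a ring, is the only measured change in the set, and it did not move the number beyond the scatter.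

Compound 3 `Cc1cccc(N2C(=O)[C@H]3[C@H](ON4[C@@H]3C(=O)N(C)[C@@]43C[C@H](C)CC[C@H]3C(C)C)C2=O)c1` has not yet been measured. It differs from compound 2 in one place: 3-methylphenyl in place of 4-methoxyphenyl on an amide-type nitrogen in a ring. Among the compounds with values here, no measured step swaps one aryl group for another on that nitrogen; the one step available exchanged methyl for 4-methoxyphenyl there without a change beyond the scatter. On that basis no step beyond the scatter is expected from compound 2 to compound 3, and the estimated step is a number 2.5 percentage points lower from compound 2 to compound 3 (within the scatter). In this assay compound 3 is therefore expected to give 42%, with a range from 28% to 56%.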

Compound 3, a percentage reported as activity, at one concentration (the size of the read-out at that concentration, not a potency): 25%
Compound 3: middle estimate off by 17 percentage points, on the high side; measured number outside the range, below it.
By their numbers in this assay, from the lowest: compound 3; then compounds 1 and 2 (each within the scatter of the next).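

In this assay, going by these compounds alone, the amide-type nitrogen now shows a change beyond the scatter for the first time: 3-methylphenyl in place of 4-methoxyphenyl gives a number 19.5 percentage points lower from compound 2 to compound 3 (beyond the scatter) and 3-methylphenyl in place of methyl gives a number 11.5 percentage points lower from compound 1 to compound 3 (beyond the scatter) on the same read-out. Carrying a six-membered aromatic ring at this nitrogen therefore does not by itself fix the number, as the 4-methoxyphenyl of compound 2 stays within the scatter of the methyl of compound 1, whereas the 3-methylphenyl of compound 3 stands apart from both. The position responds to which aryl group it carries, and the two aryl groups shown are not interchangeable here. Nothing available accounts for this step.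

The compounds shown leave open whether the lower number of compound 3 goes with the methyl group, with the loss of the methoxy group or with the place of the group on the aromatic ring, as 3-methylphenyl differs from 4-methoxyphenyl in both kind and place. Unsubstituted phenyl, 4-methylphenyl and 3-methoxyphenyl on the same nitrogen would separate these readings.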